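Difluorophenyl to Trifluoromethylphenyl on the Shared Core

This account rests on a few compounds, and the source may have more. Where it says the series, first, only, none or still open, it means among the compounds named here.

Compound 2 `O=C(O)c1ccc2nc(N3CCC(OCc4c(-c5c(F)cccc5F)noc4C4CC4)CC3)sc2c1` stands lowest of the two measured compounds: in an assay on cells for agonist activity at Bile acid receptor (Homo sapiens), read by HTRF, with a stated time of 1 h (on this read-out higher numbers stand for larger maximal responses and lower numbers for smaller maximal responses), compound 2 gives 84%, whereas compound 1 `O=C(O)c1ccc2nc(N3CCC(OCc4c(-c5c(Cl)cccc5Cl)noc4C4CC4)CC3)sc2c1` gives 96%, the step being a number 12 percentage points lower from compound 1 to compound 2 (beyond the scatter). Compound 3 `O=C(O)c1ccc2nc(N3CCC(OCc4c(-c5ccccc5C(F)(F)F)noc4C4CC4)CC3)sc2c1` differs from compound 2 by 2-(trifluoromethyl)phenyl in place of 2,6-difluorophenyl on an aromatic carbon. Going by the values given here, no measured step covers this exact exchange; the single known step at the same aromatic carbon was modest, so the change to compound 3 is expected to stay of modest size and without a clear direction. The expected step is a number 1 percentage points higher from compound 2 to compound 3 (within the scatter). Compound 3 is therefore estimated at 85%, with a likely range from 65% to 100%.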

Compound 3, largest response reached (reported as efficacy), in percent of the reference or control that the assay uses in the Bile acid receptor assay: 97%
Estimate against measurement, compound 3: 12 percentage points below; measured number inside the range.
By their numbers in the Bile acid receptor assay, from the lowest: compound 2; then compounds 1 and 3 (each within the scatter of the next).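

In the Bile acid receptor assay, 2-(trifluoromethyl)phenyl at this aromatic carbon lies clearly above 2,6-difluorophenyl (a number 13 percentage points higher from compound 2 to compound 3 (beyond the scatter)) and level with 2,6-dichlorophenyl (a number 1 percentage points higher from compound 1 to compound 3 (within the scatter)), so among these three groups only 2,6-difluorophenyl stands apart. In a physicochemical assay for solubility, in simulated intestinal fluid, at pH 6.8 (a lower number here means a less soluble compound, a higher number a more soluble compound), compound 2 gives 169000 nM and compound 3 gives 131000 nM (a 1.3-fold lower number from compound 2 to compound 3 (0.11 log units; within the scatter)), so the two stand level on solubility. Nothing at hand gives a reason for the difference in response. Open, on these data alone, is whether a methoxy or nitrile group on this phenyl ring would keep the response.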